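This account rests on a few compounds, and the source may have more. Where it says the series, first, only, none or still open, it means among the compounds named here.

Measured compounds:
- Compound 1 `COc1ncnc2c1c(-c1ccoc1)cn2[C@@H]1O[C@H](CO)[C@@H](O)[C@H]1O`: in a functional assay on K562 cells (Homo sapiens), read by MTT assay, with a stated time of 72 h (on this read-out lower numbers stand for stronger inhibition and higher numbers for weaker inhibition), compound 1 gives 190 nM.
- Compound 2 `CN(C)c1ncnc2c1c(-c1ccoc1)cn2[C@@H]1O[C@H](CO)[C@@H](O)[C@H]1O`: in this assay compound 2 gives 1540 nM.
- Compound 3 `Cc1ncnc2c1c(-c1ccoc1)cn2[C@@H]1O[C@H](CO)[C@@H](O)[C@H]1O`: in this assay compound 3 reaches only the assay limit, > 20000 nM, which is a limit and not a number.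

Compound 3 thus stands at the weak end of the three values, at the limit of > 20000 nM in this assay, at which 1 of the 3 values shown sits. The step from compound 1 to compound 3 is an at least 100-fold higher number from compound 1 to compound 3 (2.02 log units; beyond the scatter), and from compound 2 to compound 3 it is an at least 12-fold higher number from compound 2 to compound 3 (1.11 log units; beyond the scatter), so the methyl group is the poorest of the three substituents at this position, while the methoxy and dimethylamino groups differ by an 8.1-fold higher number from compound 1 to compound 2 (0.91 log units; beyond the scatter).

Compound 4 `CSc1ncnc2c1c(-c1ccoc1)cn2[C@@H]1O[C@H](CO)[C@@H](O)[C@H]1O` carries a methylsulfanyl group: methylsulfanyl in place of methyl on an aromatic carbon. Within the data shown here, the steps that bear on it are those that exchange the methyl for a heteroatom-linked group; both were large. A methylsulfanyl group resembles methoxy and dimethylamino more than methyl, so a large step downward in this assay is expected, an at least 40-fold lower number from compound 3 to compound 4 (1.60 log units; beyond the scatter), likely landing between compound 1 and compound 2. Compound 4 is estimated at 500 nM in this assay, within 150 nM to 3000 nM.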

Compound 4, half-maximal inhibitory concentration: 60 nM
Compound 4: middle estimate off by 8.3-fold (0.92 log units), on the high side; measured number below the stated range.
By their numbers in this assay, from the lowest: compound 4; then compound 1; then compound 2. At a limit, above all of these: compound 3.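

In this assay, methylsulfanyl on this aromatic carbon surpasses the best earlier group, methoxy, a 3.2-fold lower number from compound 1 to compound 4 (0.50 log units; beyond the scatter), and the margin over dimethylamino is wider, a 26-fold lower number from compound 2 to compound 4 (1.41 log units; beyond the scatter), making compound 4 the strongest of the four. The exchange of methyl for methylsulfanyl spans the widest range seen at this position, an at least 330-fold lower number from compound 3 to compound 4 (2.52 log units; beyond the scatter), and shows that a sulfur-linked group can exceed the oxygen-linked and nitrogen-linked groups here. Compound 3 gives a limit and not a number, so that step has no upper bound: the limit of > 20000 nM in this assay, at which 1 of the 4 values shown sits.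

On these data alone, whether the advantage of methylsulfanyl belongs to the sulfur alone or also depends on the methyl on it remains open, and a free thiol or a longer chain such as ethylsulfanyl would bear on that. As far as these compounds go, how a primary amine or a chlorine at this position would rank against these four groups also remains open.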